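The source may hold more compounds than are shown below. What is called first, only, known or untested is meant among the compounds shown, and "the series" means these compounds.

Compound 1, `COc1cc(OC)c(/C=C/[S+]([O-])Cc2ccc(OC)c(N)c2)c(OC)c1`, gives 40 nM in a functional assay on DU-145 cells (Homo sapiens) for cytotoxicity, read by trypan blue exclusion, with a stated time of 96 h; a higher number here means a weaker inhibitor, a lower number a stronger inhibitor.
Compound 2, `COC(=O)[C@H](C)Nc1cc(CS(=O)(=O)/C=C/c2c(OC)cc(OC)cc2OC)ccc1OC`, gives 750 nM in this assay.

Of these two numbers, compound 2 holds the higher one, and its gap to compound 1 lies beyond the usual scatter of repeated measurements, so compound 2 is the weaker inhibitor of the pair. Compound 3, `COc1ccc(C(Nc2cc(CS(=O)(=O)/C=C/c3c(OC)cc(OC)cc3OC)ccc2OC)C(=O)O)cc1`, has not yet been measured. It differs from compound 2 in one place: carboxy(4-methoxyphenyl)methyl in place of 1-(methoxycarbonyl)ethyl on a nitrogen on an aromatic ring. The rest of the shared core is kept; only the group on the nitrogen changes. For the measured compounds named here, no measured pair here shows what such a change does, so the expectation rests on compound 2 alone. The step in this assay is expected to be a 2.0-fold higher number from compound 2 to compound 3 (0.30 log units; within the scatter), a modest rise in the number, though a result within the scatter would not be surprising. For compound 3 the estimated value in this assay is 1500 nM, with a range from 400 nM to 6000 nM.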

Compound 3, half-maximal inhibitory concentration: 100 nM
Estimate against measurement, compound 3: 15-fold (1.18 log units) above, outside the stated range (below it).
By their numbers in this assay, from the lowest: compound 1; then compound 3; then compound 2.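

In this assay, the nitrogen on the aromatic ring accepts a much larger group without losing activity: carboxy(4-methoxyphenyl)methyl in place of 1-(methoxycarbonyl)ethyl gives a 7.5-fold lower number from compound 2 to compound 3 (0.88 log units; beyond the scatter), a gain rather than a loss. This single swap changes several things at once, since the entering group adds an aromatic ring, carries a free carboxy group instead of a methyl ester, brings a hydrogen-bond donor and has no defined stereocentre. Nothing measured here explains why the number falls.

The compounds shown leave open whether the aromatic ring or the carboxy group accounts for the step. A 1-carboxyethyl group, or a (methoxycarbonyl)(4-methoxyphenyl)methyl group, on the same nitrogen would separate the two.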